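The source may report more compounds than this note shows. Statements on the series, on what has been measured and on what is new or still open speak of the compounds shown alone.

Compound 1 `CCc1nc(C(C)C)c2n1CCN([C@@H](C(=O)NC)c1ccccc1)C2CCc1ccc(C(F)(F)F)cc1`: 2900 nM
Compound 2 `CNC(=O)[C@@H](c1ccccc1)N1CCn2c(C(C)C)nc(Cl)c2[C@@H]1CCc1ccc(C(F)(F)F)cc1`: 11 nM

Both numbers come from a functional assay on CHO cells for antagonist activity at Orexin receptor type 2 (Homo sapiens), read by FLIPR and calcium flux; a higher number here means a weaker inhibitor, a lower number a stronger inhibitor. Compound 1 stands at the higher of the two values, and compound 2 sits at a much lower number, far outside the usual scatter. Compound 3 `CCc1ncc2n1CCN([C@@H](C(=O)NC)c1ccccc1)C2CCc1ccc(C(F)(F)F)cc1` is not yet measured. It differs from compound 1 by one change, (hydrogen in place of isopropyl on an aromatic carbon), hydrogen in place of isopropyl on an aromatic carbon. Within the data shown here, no measured pair shows this change, so the size of its effect is unknown; a modest rise is expected, possibly within the scatter. Compound 3 is expected to give 4500 nM, with a range from 1200 nM to 18000 nM. This estimate means a step of a 1.6-fold higher number from compound 1 to compound 3 (0.19 log units; within the scatter) in this assay.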

Compound 3, half-maximal inhibitory concentration: 194 nM
Compound 3: middle estimate off by 23-fold (1.37 log units), on the high side; the whole stated range lies above it.
By their numbers in this assay, from the lowest: compound 2; then compound 3; then compound 1.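

Putting hydrogen in place of isopropyl on this aromatic carbon gives a 15-fold lower number from compound 1 to compound 3 (1.17 log units; beyond the scatter) in this assay. The position is therefore sensitive to this change, and on this core the compound without the isopropyl is the stronger inhibitor. No measurement shown here explains the step.

Going by these compounds, it remains open whether a methyl group or a methoxy group on this carbon would give a number closer to that of compound 3 or of compound 1. On these data alone, it is also open whether the same change would have a similar effect with different groups elsewhere on the core.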